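Quinone series: bromo in place of pentyl

This account rests on a few compounds, and the source may have more. Where it says the series, first, only, none or still open, it means among the compounds named here.

Measured so far in an assay on isolated protein for inhibition of Polyunsaturated fatty acid 5-lipoxygenase (Homo sapiens), read by ELISA, with a stated time of 10 min; on this read-out lower numbers stand for stronger inhibition and higher numbers for weaker inhibition:
compound 1 `CCCCCC1=CC(=O)C=C(OC)C1=N` – 1010 nM
compound 2 `COc1cc(O)cc(Br)c1O` – 1140 nM
compound 3 `CCCCCC1=CC(=O)C=C(OC)C1=O` – 1370 nM

The three numbers sit close together. Compound 3 stands within the usual scatter of compound 2 and also within the scatter of compound 1, so no order among the three can be read from these values; all three inhibit in the same concentration band.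

The next compound, compound 4 `COC1=CC(=O)C=C(Br)C1=O`, keeps the core of compound 3 and changes a single group: bromo in place of pentyl on a double-bonded ring carbon. Compound 2 carries a bromo as well and gives a number in the same band as compound 3, which is the only point of reference for a bromo-bearing compound here. Within the data shown here, no step between measured compounds tells how the pentyl chain itself matters. The step from compound 3 to compound 4 is therefore expected to be modest, toward a somewhat weaker inhibition, with a wide margin in both directions: a 1.8-fold higher number from compound 3 to compound 4 (0.26 log units; within the scatter). For compound 4 in this assay the estimate is 2500 nM, with a likely range from 800 nM to 8000 nM.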

Compound 4, half-maximal inhibitory concentration: 1670 nM
The estimate for compound 4 lay 1.5-fold (0.18 log units) above the measured number; measured number inside the range.
By their numbers in this assay, from the lowest: compounds 1, 2, 3 and 4 (each within the scatter of the next).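

In this assay, bromo in place of pentyl on a double-bonded ring carbon gives a 1.2-fold higher number from compound 3 to compound 4 (0.09 log units; within the scatter), so this first step at the position cannot be told apart from repeat measurement. With bromo as the replacement, the pentyl chain is therefore not needed at this carbon for inhibition to stay in the same concentration band as compound 3. No available measurement bears on why the two groups give such similar numbers.

On these data alone, it remains open whether any group at this carbon can move the number beyond the scatter; a hydrogen, a methyl, a longer chain such as octyl, or a carboxylic acid would test this. As far as these compounds go, it is also open whether the same tolerance holds when the methoxy group gives way to an ethoxy or a hydroxyl.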